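A Second Chlorine Added to Compound 2

This account rests on a few compounds, and the source may have more. Where it says the series, first, only, none or still open, it means among the compounds named here.

Of the compounds shown here, two have so far been measured in an assay on CHO cells for displacement of a labelled ligand from adenosine receptor A2b (Homo sapiens), read by scintillation counting, with a stated time of 75 min; on this read-out lower numbers stand for stronger inhibition and higher numbers for weaker inhibition. Compound 1 `O=C(CCCc1ccccc1)Nc1nc2ccsc2c(=O)s1` gives 547 nM in this assay. Compound 2 `O=C(C/C=C/c1cccc(Cl)c1)Nc1nc2ccccc2c(=O)s1` stands differently: for compound 2 this assay reports only a limit, > 1000 nM, and no number. That limit is the one described by the limit of > 1000 nM in this assay, at which 1 of the 2 values shown sits, and it leaves the true value of compound 2 open above the range the assay resolves.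

Compound 3 `O=C(C/C=C/c1ccc(Cl)c(Cl)c1)Nc1nc2ccccc2c(=O)s1` is not yet measured. It differs from compound 2 by chloro in place of hydrogen on an aromatic carbon, so that the 3-chlorophenyl of compound 2 becomes a 3,4-dichlorophenyl. For the measured compounds named here, no measured pair in this set carries the same change, so nothing here shows its size or direction. The expectation is therefore a step of no more than the usual scatter, in neither direction with any confidence, and the step expected from compound 2 to compound 3 in this assay is a step that the limit leaves unreadable from compound 2 to compound 3. Since compound 2 sits at the limit, compound 3 is expected to land near or beyond it, with an estimated value of 1500 nM in this assay and a range from 500 nM to 6000 nM.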

Compound 3, inhibition constant: > 1000 nM
Compound 3: a limit, no number (the forecaster's own chance of this, stated with the estimate: 55%); the middle value does not contradict the limit.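

No step can be read between compound 2 and compound 3 in this assay, because each of the two reports only a limit and no number: the limit of > 1000 nM in this assay, at which 2 of the 3 values shown sit.

The compounds shown leave open whether the 3,4-dichlorophenyl of compound 3 binds differently from the 3-chlorophenyl of compound 2, and where either true value lies.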